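The source may report more compounds than this note shows. Statements on the series, on what has been measured and on what is new or still open speak of the compounds shown alone.

Of the compounds shown here, three built on one shared core have been tested in a functional assay on mitochondria from heart for inhibition of peroxisomal acyl-coenzyme A oxidase 1 (Rattus norvegicus); on this read-out lower numbers stand for stronger inhibition and higher numbers for weaker inhibition. Compound 1 `Cc1nc2cc(OC[C@H](O)CN3CCN(Cc4noc(-c5ccc(Cl)cc5)n4)CC3)ccc2s1` gives 2270 nM, compound 2 `Cc1nc2cc(OC[C@H](O)CN3CCN(Cc4noc(-c5ccc(Cl)c(Cl)c5)n4)CC3)ccc2s1` gives 550 nM, and compound 3 `Cc1nc2cc(OC[C@H](O)CN3CCN(Cc4noc(-c5ccc(C#N)cc5)n4)CC3)ccc2s1` gives 4410 nM. Compound 3 stands apart from compound 2, since an 8.0-fold higher number from compound 2 to compound 3 (0.90 log units; beyond the scatter) lies beyond the scatter, but not from compound 1, since a 1.9-fold higher number from compound 1 to compound 3 (0.29 log units; within the scatter) lies within it. Compound 4 `Cc1nc2cc(OC[C@H](O)CN3CCN(Cc4noc(-c5cccc(F)c5)n4)CC3)ccc2s1` differs from compound 3 by 3-fluorophenyl in place of 4-cyanophenyl on an aromatic carbon. Within the data shown here, two measured steps bear on this: a 1.9-fold higher number from compound 1 to compound 3 (0.29 log units; within the scatter) and a 4.1-fold lower number from compound 1 to compound 2 (0.62 log units; beyond the scatter). Compound 1, which carries a chloro where compound 3 carries the cyano, gave a number close to that of compound 3, so only a small shift is expected in this assay, a 1.7-fold lower number from compound 3 to compound 4 (0.23 log units; within the scatter). Compound 4 is therefore estimated at 2600 nM, between 900 nM and 7500 nM.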

Compound 4, half-maximal inhibitory concentration: 13400 nM
The estimate for compound 4 lay 5.2-fold (0.71 log units) below the measured number; the measured number lies above the stated range.
By their numbers in this assay, from the lowest: compound 2; then compounds 1 and 3 (each within the scatter of the next); then compound 4.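

Among these compounds, the aryl group at this position can weaken inhibition further than the earlier compounds showed in this assay: a 3.0-fold higher number from compound 3 to compound 4 (0.48 log units; beyond the scatter) is joined by a 5.9-fold higher number from compound 1 to compound 4 (0.77 log units; beyond the scatter) and by a 24-fold higher number from compound 2 to compound 4 (1.39 log units; beyond the scatter), leaving 3-fluorophenyl the weakest of the four groups. No measurement shown here explains this rise.

On these data alone, whether the loss follows from the fluoro itself or from where it sits on the phenyl ring stays open. Also open, as far as these compounds go, is how a phenyl ring carrying a methoxy or an amine would compare.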